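Amino in place of hydroxy on compound 2

This account rests on a few compounds, and the source may have more. Where it says the series, first, only, none or still open, it means among the compounds named here.

Compound 1 `COc1ccc(-c2ss/c(=N/O)c2-c2cc(OC)c(OC)c(OC)c2)cc1N` gives 4300 nM
Compound 2 `CO/N=c1/ssc(-c2ccc(OC)c(O)c2)c1-c1cc(OC)c(OC)c(OC)c1` gives 10000 nM

In a functional assay on SGC-7901 cells (Homo sapiens) for antiproliferative activity, read by MTT assay, with a stated time of 72 h (on this read-out lower numbers stand for stronger inhibition and higher numbers for weaker inhibition), compound 2 gives 10000 nM as the higher of the two numbers, beyond the usual scatter from compound 1. Compound 3 `CO/N=c1/ssc(-c2ccc(OC)c(N)c2)c1-c1cc(OC)c(OC)c(OC)c1` differs from compound 2 by amino in place of hydroxy on an aromatic carbon. In this assay compound 1, which also carries the 3-amino-4-methoxyphenyl group, gives 4300 nM but differs from compound 2 elsewhere too. A step to a lower number, somewhat beyond the scatter, is therefore expected (a 2.9-fold lower number from compound 2 to compound 3 (0.46 log units; beyond the scatter)). The estimate for compound 3 is 3500 nM (expected range 800 nM to 12000 nM).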

Compound 3, half-maximal inhibitory concentration: > 100000 nM
Compound 3: only a limit was reported; the forecaster's own chance of this, stated with the estimate: 10%; middle value at least 28-fold (1.45 log units) from the limit.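

In this assay compound 3 gives > 100000 nM, which is a limit and not a number: the limit of > 100000 nM in this assay, at which 1 of the 3 values shown sits.

Amino in place of hydroxy at this position gives an at least 10-fold higher number from compound 2 to compound 3 (1.00 log units; beyond the scatter), so the change does not help when methyl sits on the oxygen. Methyl in place of hydrogen on that oxygen gives an at least 23-fold higher number from compound 1 to compound 3 (1.36 log units; beyond the scatter), so the outcome for the 3-amino-4-methoxyphenyl group depends on a second place in the molecule.

On these data alone, both steps rest on a limit, so their true sizes remain open. Also open, as far as these compounds go, is whether fluorine or an acetamide at this position, or ethyl on that oxygen, would fare better.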